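From a Bromophenyl Arm to a Trifluoromethylphenyl Arm

The compounds below may be only part of what the source reports. "The series", "measured", "known", "first", "only" and "open" are said of these compounds alone.

Of the compounds shown here, three sharing one core have been tested in a functional assay on U-937 cells (Homo sapiens) for cytotoxicity, read by CCK-8 assay, with a stated time of 72 h; on this read-out lower numbers stand for stronger inhibition and higher numbers for weaker inhibition. Compound 1 `C=CCn1c(=O)/c(=C\c2cccc(Cl)c2Cl)[nH]c(=O)/c1=C\c1ccccc1OC` gives 500 nM, compound 2 `C=CCn1c(=O)/c(=C\c2cc(Br)ccc2F)[nH]c(=O)/c1=C\c1ccccc1OC` gives 4700 nM, and compound 3 `C=CCn1c(=O)/c(=C\c2cccc(Br)c2)[nH]c(=O)/c1=C\c1ccccc1OC` gives 1100 nM, which places compound 3 second highest of the three, nearer to compound 1 than to compound 2. Compound 4 `C=CCn1c(=O)/c(=C\c2ccccc2C(F)(F)F)[nH]c(=O)/c1=C\c1ccccc1OC` has not yet been measured. The change is 2-(trifluoromethyl)phenyl in place of 3-bromophenyl on a double-bonded chain carbon bound to an aromatic carbon. Among the measured compounds shown here, no measured step brings in a trifluoromethyl group, so the guidance is indirect: a 2.2-fold higher number from compound 1 to compound 3 (0.34 log units; beyond the scatter) and a 4.3-fold lower number from compound 2 to compound 3 (0.63 log units; beyond the scatter), modest steps that pull in opposite directions for substituents on this phenyl. For compound 4 the expected step in this assay is a 1.4-fold higher number from compound 3 to compound 4 (0.13 log units; within the scatter), small and of uncertain direction. Compound 4 is estimated at 1500 nM, with a range from 400 nM to 6000 nM.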

Compound 4, half-maximal inhibitory concentration: 1500 nM
For compound 4 middle estimate and measured number coincide at the digits printed; the measured number falls inside the stated range.
By their numbers in this assay, from the lowest: compound 1; then compounds 3 and 4 (each within the scatter of the next); then compound 2.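

In this assay, the phenyl arm at this position accepts a trifluoromethyl group in place of bromine with no readable shift, giving a 1.4-fold higher number from compound 3 to compound 4 (0.13 log units; within the scatter) despite the larger group. Compound 4 also stands apart from the two ends of the series, with a 3.1-fold lower number from compound 2 to compound 4 (0.50 log units; beyond the scatter) and a 3.0-fold higher number from compound 1 to compound 4 (0.48 log units; beyond the scatter). No measurement shown here gives a reason for any of these steps. From the compounds shown here alone, how a phenyl arm carrying an amine or a carboxylic acid would read in this assay remains open.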